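Methyl for Trifluoromethyl on an Oxadiazole Ring

The compounds below may be only part of what the source reports. "The series", "measured", "known", "first", "only" and "open" are said of these compounds alone.

Measured so far:
compound 1 `Cn1nnc(C2=NN(c3ccc(S(N)(=O)=O)cc3)C(c3ccc(Cl)cc3)C2)n1` gives 23.7%
compound 2 `FC(F)(F)c1nc(C2=NN(c3ccccc3)C(c3ccc(Cl)cc3)C2)no1` gives 15.8%

Both compounds were tested in a functional assay on the whole organism (strain Wistar) for inhibition, with Rattus norvegicus as the target, in the writhing test, with stated times of 1 h and 30 min, at a dose of 100 mg/kg by the oral route; a lower number here means less inhibition, a higher number more inhibition at the dose given (going by the name of the read-out). Compound 1 gives 23.7% and compound 2 gives 15.8%. Compound 2 sits at one end of these two numbers, but the gap from compound 1 lies within the usual scatter, so the two cannot be told apart on this evidence.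

Compound 3 `Cc1nc(C2=NN(c3ccccc3)C(c3ccc(Cl)cc3)C2)no1` has not yet been measured. It differs from compound 2 in one place: methyl in place of trifluoromethyl on an aromatic carbon. Going by the values given here, no measured pair in this set shows what such a swap does, so there is no step to lean on; the only anchor is the value of compound 2.

For compound 3 the expectation is therefore a step of a number 0.2 percentage points higher from compound 2 to compound 3 (within the scatter), that is, no change beyond the scatter. Compound 3 is estimated at 16%, with a range from 4% to 30%.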

Compound 3, a percentage reported as inhibition, in the whole organism at one dose (the size of the read-out at that dose, not a potency): 23.7%
Beside the measured number, compound 3's estimate is 7.7 percentage points below it, within the range that was stated.
By their numbers in this assay, from the lowest: compounds 2, 1 and 3 (each within the scatter of the next).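

Going by these compounds alone, putting methyl in place of trifluoromethyl on this five-membered aromatic ring, with the rest of the molecule unchanged, gives a number 7.9 percentage points higher from compound 2 to compound 3 (within the scatter) in this assay and is the first direct test of this position. The two groups therefore cannot be told apart here: at this single dose, the smaller methyl group serves as well as trifluoromethyl as far as this test can show. Nothing available explains this result or links it to any property of either group.

From the compounds shown here alone, it remains open whether a larger change at this position, such as an amine, a carboxylic acid or a longer chain, would move the number beyond the scatter. A single dose also leaves open whether compound 2 and compound 3 would still read alike at other doses.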